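A few compounds are considered here, and "the series" means these few. Any claim that something is new, unique, unknown or untested is made for them only; others in the source may bear on it.

In a functional assay on PC-3 cells (Homo sapiens) for cytotoxicity (on this read-out higher numbers stand for an effect only at larger amounts of compound and lower numbers for an effect already at smaller amounts), compound 1 `COC1=C(C)C(=O)/C(=C(O)/C=C/c2ccc(OC)cc2)C(=O)C1(C)C` gives 18.2 ug/mL, compound 2 `COC1=C(C)C(=O)/C(=C(O)/C=C/c2ccc(F)cc2)C(=O)C1(C)C` gives 7.2 ug/mL and compound 3 `COC1=C(C)C(=O)/C(=C(O)/C=C/c2cc(C)cc(C)c2)C(=O)C1(C)C` gives 8.8 ug/mL. The three compounds differ only in the aromatic group on the chain. Compound 3 stands with compound 2 rather than with compound 1: a 1.2-fold higher number from compound 2 to compound 3 (0.09 log units; within the scatter) stays within the scatter, whereas a 2.1-fold lower number from compound 1 to compound 3 (0.32 log units; beyond the scatter) and a 2.5-fold lower number from compound 1 to compound 2 (0.40 log units; beyond the scatter) are modest moves beyond it. Compound 4 `C=Cc1ccccc1/C=C/C(O)=C1/C(=O)C(C)=C(OC)C(C)(C)C1=O` changes that aromatic group again, with 2-vinylphenyl in place of 3,5-dimethylphenyl on a double-bonded chain carbon bound to a double-bonded chain carbon. For the measured compounds named here, no measured compound carries a vinyl group, so the evidence is only indirect. Like compound 3, compound 4 lacks the methoxy of compound 1, so the nearest guide is a 1.2-fold higher number from compound 2 to compound 3 (0.09 log units; within the scatter), and no step beyond the scatter is expected in this assay, in either direction. The expected step is a 1.0-fold higher number from compound 3 to compound 4 (0.01 log units; within the scatter). For compound 4 the estimated value is 9 ug/mL, with an expected range from 4 ug/mL to 20 ug/mL.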

Compound 4, concentration for half-maximal effect: 4.6 ug/mL
Compound 4: the middle estimate sits 2.0-fold (0.29 log units) above what was measured; the measured number falls inside the stated range.
By their numbers in this assay, from the lowest: compounds 4, 2 and 3 (each within the scatter of the next); then compound 1.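

In this assay, the 2-vinylphenyl group of compound 4 joins the 4-fluorophenyl and 3,5-dimethylphenyl groups on a double-bonded chain carbon, with a 1.9-fold lower number from compound 3 to compound 4 (0.28 log units; within the scatter) and a 1.6-fold lower number from compound 2 to compound 4 (0.19 log units; within the scatter). Compound 1 now stands apart from three differently substituted compounds rather than two, and a 4.0-fold lower number from compound 1 to compound 4 (0.60 log units; beyond the scatter) is a modest step, so a double bond outside the aromatic ring is accommodated here without a separation from compound 2 or compound 3 in this read-out. Nothing shown here explains the values or the separate standing of compound 1.

The compounds shown leave open whether an aromatic ring carrying an amine or a carboxylic acid would stay with compounds 2, 3 and 4. They also leave open whether an ethyl group would give a value like that of the 2-vinylphenyl compound.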